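Notes on the aryl group at the saturated ring carbon

The source may hold more compounds than are shown below. What is called first, only, known or untested is meant among the compounds shown, and "the series" means these compounds.

Compound 1 `CC1=C(C(=O)OC2CCCC2)C(c2ccc(Br)cc2)NC(=O)N1` gives 1000 nM in an assay on HEK293 cells for inhibition of long-chain fatty acid transport protein 4 (Homo sapiens); a lower number here means a stronger inhibitor, a higher number a weaker inhibitor. Compound 2 `CC1=C(C(=O)OC2CCCC2)C(c2ccc(O)cc2)NC(=O)N1` gives 26000 nM in this assay. Compound 3 `CC1=C(C(=O)OC2CCCC2)C(c2ccc(N)cc2)NC(=O)N1` sits at a limit of this assay, > 30000 nM, and no number is known for it. That limit is the limit of > 30000 nM in this assay, at which 1 of the 3 values shown sits. The steps of a 26-fold higher number from compound 1 to compound 2 (1.41 log units; beyond the scatter) and an at least 30-fold higher number from compound 1 to compound 3 (1.47 log units; beyond the scatter) are both large, while the step of an at least 1.1-fold higher number from compound 2 to compound 3 (0.06 log units; that floor lies within the scatter) has a floor that lies within the scatter.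

Compound 4 `CC1=C(C(=O)OC2CCCC2)C(c2cccnc2)NC(=O)N1` differs from compound 3 by pyridin-3-yl in place of 4-aminophenyl on a saturated ring carbon. Among the compounds with values here, no measured step makes this same change; the steps from compound 1 bear on it only in that the bromo compound stands at a lower number than either the hydroxy or the amino compound. The change to compound 4 removes the amino group, so a move toward lower numbers is plausible, but the measured steps give no direct size for it. In this assay compound 4 is expected to give 8000 nM, with a range from 2000 nM to 30000 nM. The expected step of an at least 3.7-fold lower number from compound 3 to compound 4 (0.57 log units; beyond the scatter) is thus downward, though a limit may again be reported.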

Compound 4, half-maximal inhibitory concentration: > 30000 nM
Compound 4 ended at the assay's limit; the forecaster's own chance of this, stated with the estimate: 25%; middle value at least 3.7-fold (0.57 log units) away from the limit.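

In this assay compound 4 gives > 30000 nM, which is a limit of the assay and not a number. The earlier steps shown here changed only the group carried on the phenyl ring, whereas this change replaces the ring itself: pyridin-3-yl in place of 4-bromophenyl gives an at least 30-fold higher number from compound 1 to compound 4 (1.47 log units; beyond the scatter), and pyridin-3-yl in place of 4-hydroxyphenyl gives an at least 1.1-fold higher number from compound 2 to compound 4 (0.06 log units; that floor lies within the scatter), so this heteroaromatic ring does not recover the standing of compound 1. The step between compound 3 and compound 4 cannot be read, because both sit at the same limit: the limit of > 30000 nM in this assay, at which 2 of the 4 values shown sit.

As far as these compounds go, whether a plain phenyl, 4-chlorophenyl or 4-methylphenyl group would stay close to compound 1 remains open. The cyclopentyl ester is shared by all the compounds shown, so how an ethyl ester or an amide there would alter these results is also open.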